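Swapping the methylene link for an oxygen bridge

The source may report more compounds than this note shows. Statements on the series, on what has been measured and on what is new or still open speak of the compounds shown alone.

Measured compounds in a functional assay for agonist activity at Free fatty acid receptor 1 (Homo sapiens), read by FLIPR, in the presence of a further agent that is not named here; a lower number here means that less compound is needed, a higher number that more compound is needed for the effect:
compound 1 `Cc1cc(Oc2ccc(CC3SC(=O)NC3=O)cc2)cc(C)c1C#N` — 120 nM
compound 2 `O=C1NC(=O)C(Cc2ccc(Cc3ccccc3)cc2)S1` — 9280 nM
compound 3 `O=C1NC(=O)C(Cc2ccc(CCc3ccccc3)cc2)S1` — 1080 nM

Compound 2 gives the highest number of the three. Its closest neighbour is compound 3, which differs from it by benzyl in place of phenyl on a saturated chain carbon bound to an aromatic carbon, a step of an 8.6-fold lower number from compound 2 to compound 3 (0.93 log units; beyond the scatter). Furthest away is compound 1, whose value of 120 nM is far lower than that of compound 2; the two differ in several places at once, so no single step links them.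

The unmeasured compound 4 `O=C1NC(=O)C(Cc2ccc(Oc3ccccc3)cc2)S1` differs from compound 2 in one place: phenoxy in place of benzyl on an aromatic carbon. Compound 1 shares that phenoxy linkage, carrying additional groups on its outer ring, and gives the lowest number of the set. Lengthening the link in compound 3 already brought the number down. Taken together, the oxygen-bridged compound 4 is expected to sit between compound 3 and compound 1, giving a step of a 6.2-fold lower number from compound 2 to compound 4 (0.79 log units; beyond the scatter) from compound 2. Compound 4 is therefore estimated at 1500 nM, with a range of 500 nM to 5000 nM in this assay.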

Compound 4, half-maximal effective concentration: 307 nM
The estimate for compound 4 lay 4.9-fold (0.69 log units) above the measured number; measured number outside the range, below it.
By their numbers in this assay, from the lowest: compound 1; then compound 4; then compound 3; then compound 2.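

In this assay, the change a 30-fold lower number from compound 2 to compound 4 (1.48 log units; beyond the scatter) replaces the benzyl group with phenoxy on the same aromatic carbon, para to a group of 8 heavy atoms, and both groups have 7 heavy atoms and one six-membered aromatic ring of carbon only. The earlier step of an 8.6-fold lower number from compound 2 to compound 3 (0.93 log units; beyond the scatter) lengthened the group, so it could not show that the number at this position also responds to the link atom alone, with the size of the group held at the same heavy-atom count: one carbon gives way to one oxygen, and the hydrogen-bond acceptor count of the group goes from 0 to 1. No measurement at hand explains why this exchange has so large an effect.

Going by these compounds, whether a sulfur atom or an amine as the link would read like the oxygen of compound 4 or like the methylene of compound 2 remains open. On these data alone, it is also open how a nitrile alone or methyl groups alone on the outer ring of compound 4 would read, as compound 1 carries them together.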